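The source may hold more compounds than are shown below. What is called first, only, known or untested is meant among the compounds shown, and "the series" means these compounds.

Working notes on the series. Of the compounds shown here, three have numbers so far. Compound 1 `CCS(=O)(=O)Nc1cc(-c2ccc3ncnc(Nc4cccc(F)c4)c3c2)cnc1OC` gives 9940 nM in a functional assay on A549 cells (Homo sapiens) for cytotoxicity, read by sulforhodamine B assay, with a stated time of 72 h; on this read-out lower numbers stand for stronger inhibition and higher numbers for weaker inhibition. Compound 2 `CCS(=O)(=O)Nc1cc(-c2ccc3ncnc(Nc4ccc(OC)cc4)c3c2)cnc1OC` gives 3580 nM in this assay, and compound 3 `CCS(=O)(=O)Nc1cc(-c2ccc3ncnc(Nc4ccc(OC)c(OC)c4)c3c2)cnc1OC` gives 5820 nM. The step of a 2.8-fold lower number from compound 1 to compound 2 (0.44 log units; beyond the scatter) is the only one beyond the scatter; the steps of a 1.7-fold lower number from compound 1 to compound 3 (0.23 log units; within the scatter) and a 1.6-fold higher number from compound 2 to compound 3 (0.21 log units; within the scatter) are not. Compound 3 therefore stands second highest of the three numbers, within the scatter of both compound 2 and compound 1, so no order among these two and compound 3 can be read from the numbers.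

The next member is compound 4 `CCS(=O)(=O)Nc1cc(-c2ccc3ncnc(Nc4ccc(C(=O)OC)c(OC)c4)c3c2)cnc1OC`. Its difference from compound 3 is methoxycarbonyl in place of methoxy on an aromatic carbon. Within the data shown here, none of the measured steps exchanges a methoxy for a methoxycarbonyl; the measured steps all concern the group on the nitrogen and stayed small, the largest being a 2.8-fold lower number from compound 1 to compound 2 (0.44 log units; beyond the scatter) and the others within the scatter. With no closer comparison in hand, no step beyond the scatter is expected in this assay for compound 4, with a wide range to cover the lack of a direct precedent.

The expected step is a 1.0-fold higher number from compound 3 to compound 4 (0.01 log units; within the scatter) for compound 4. Compound 4 is thus estimated at 6000 nM in this assay, within a range from 2000 nM to 18000 nM.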

Compound 4, half-maximal inhibitory concentration: 3350 nM
Compound 4: the middle estimate sits 1.8-fold (0.25 log units) above what was measured; the range from low to high includes it.
By their numbers in this assay, from the lowest: compounds 4, 2, 3 and 1 (each within the scatter of the next, the first and the last beyond it).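

In this assay, methoxycarbonyl in place of methoxy on this aromatic carbon, para to a large group and ortho to a methoxy group, gives no change that can be read (a 1.7-fold lower number from compound 3 to compound 4 (0.24 log units; within the scatter)), so the larger group, with its added carbonyl, leaves the number within the scatter of compound 3. The 3-methoxy-4-(methoxycarbonyl)phenyl group also stands level with 4-methoxyphenyl (a 1.1-fold lower number from compound 2 to compound 4 (0.03 log units; within the scatter)), while against 3-fluorophenyl it gives the second step beyond the scatter in the series (a 3.0-fold lower number from compound 1 to compound 4 (0.47 log units; beyond the scatter)), modest in size and close to the earlier step from the same compound (a 2.8-fold lower number from compound 1 to compound 2 (0.44 log units; beyond the scatter)). Nothing at hand bears on the reason for these numbers.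

The compounds shown leave open how a carboxylic acid, an amide or an amine would read on this aromatic carbon, and whether a longer chain in place of the methoxy of the methoxycarbonyl group would keep the number within the scatter of compound 4. They also leave open whether methoxycarbonyl reads the same without the methoxy group ortho to it.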